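The source may report more compounds than this note shows. Statements on the series, on what has been measured and on what is new or still open speak of the compounds shown alone.

In a functional assay on MCF7 cells (Homo sapiens) for antiproliferative activity, read by MTT assay, with a stated time of 72 h (on this read-out lower numbers stand for stronger inhibition and higher numbers for weaker inhibition), compound 3 `CCn1cc(C(CC)(CC)c2ccc(C#CC(O)(CC)CC)c(C)c2)cc1C(=O)NCCCN(C)C` gives 20200 nM. That is within the usual scatter of compound 2 `CCn1c(C(=O)N[C@H](C(=O)O)C(C)C)ccc1C(CC)(CC)c1ccc(C#CC(O)(CC)CC)c(C)c1` at 13000 nM, and a higher number than compound 1 `CCn1c(C(=O)NCC(=O)O)ccc1C(CC)(CC)c1ccc(C#CC(O)(CC)CC)c(C)c1` at 5140 nM. Compound 4 `CCn1cc(C(CC)(CC)c2ccc(C#CC(O)(CC)CC)c(C)c2)cc1C(=O)N[C@@H](C)CO` carries 1-(hydroxymethyl)ethyl in place of 3-(dimethylamino)propyl on an amide-type nitrogen. Among the compounds with values here, no measured step covers this exchange. Within the data shown here, the only single change measured, a 2.5-fold higher number from compound 1 to compound 2 (0.40 log units; beyond the scatter), is modest and concerns a different amide side chain, so it offers only a rough size. Compound 1 at 5140 nM also lacks 3-(dimethylamino)propyl, but so does compound 2 at 13000 nM, so only a small move toward a lower number is expected. The estimated change is a 1.7-fold lower number from compound 3 to compound 4 (0.23 log units; within the scatter). For compound 4 the estimate is 12000 nM, with an expected range of 4500 nM to 30000 nM.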

Compound 4, half-maximal inhibitory concentration: 1910 nM
Estimate against measurement, compound 4: 6.3-fold (0.80 log units) above; the whole stated range lies above it.
By their numbers in this assay, from the lowest: compound 4; then compound 1; then compounds 2 and 3 (each within the scatter of the next).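

In this assay, the amide-type nitrogen proves to be a place where the side chain can matter greatly: 1-(hydroxymethyl)ethyl in place of 3-(dimethylamino)propyl gives an 11-fold lower number from compound 3 to compound 4 (1.02 log units; beyond the scatter) on the same core. Within the data shown here, the only earlier step, a 2.5-fold higher number from compound 1 to compound 2 (0.40 log units; beyond the scatter), was modest and concerned a different amide side chain. Nothing available explains the size of the new step. From the compounds shown here alone, it remains open whether the change follows from losing the dimethylamino end or from gaining the hydroxyl. A plain propyl or a 3-hydroxypropyl chain on this nitrogen would help separate the two.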